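The compounds below may be only part of what the source reports. "The series", "measured", "known", "first", "only" and "open" are said of these compounds alone.

Measured so far:
compound 1, `COc1cc(/C=C/C(=O)/C=C/c2cccc3ccccc23)ccc1OCc1cn(CCOc2cc(=O)oc3ccccc23)nn1`: 89%
compound 2, `COc1cc(/C=C/C(=O)/C=C/c2ccco2)ccc1OCc1cn(CCCCCOc2cc(=O)oc3ccccc23)nn1`: 39%

In a functional assay on THP-1 cells (Homo sapiens) for inhibition, read by sulforhodamine B assay, with a stated time of 48 h, tested at 50 uM (on this read-out lower numbers stand for less inhibition of growth and higher numbers for more inhibition of growth at the one concentration tested), compound 1 gives 89%, the higher of the two numbers recorded. Compound 2 gives 39% in this assay, a result far below that of compound 1; the two compounds differ in more than one place, so the two values alone are all that can be said of that gap. Compound 3, `COc1ccc(/C=C/C(=O)/C=C/c2ccc(OCc3cn(CCOc4cc(=O)oc5ccccc45)nn3)c(OC)c2)cc1`, has not been measured. It arises from compound 1 by a single change: 4-methoxyphenyl in place of naphthalen-1-yl on a double-bonded chain carbon bound to a double-bonded chain carbon. Among the measured compounds shown here, the only comparison at hand is the lower number of compound 2, whose value 39% suggests that moving away from compound 1 can cost much inhibition. A drop beyond the scatter is therefore expected, a number 24 percentage points lower from compound 1 to compound 3 (beyond the scatter), though smaller than the gap to compound 2. Compound 3 is estimated at 65%, within a range from 40% to 88%.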

Compound 3, percent growth inhibition at one concentration: 78%
Estimate against measurement, compound 3: 13 percentage points below; the range from low to high includes it.
By their numbers in this assay, from the lowest: compound 2; then compound 3; then compound 1.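

In this assay, putting 4-methoxyphenyl in place of naphthalen-1-yl gives a number 11 percentage points lower from compound 1 to compound 3 (beyond the scatter), the first effect that can be read for a single change at this place, on a double-bonded chain carbon bound to a double-bonded chain carbon. The step is modest, and the second aromatic ring of naphthalen-1-yl is not required for substantial growth inhibition, since compound 3, with one such ring, still gives 78%. No measurement at hand accounts for the loss.

The exchange removes a ring and adds a methoxy oxygen at once, so the compounds shown leave open what each contributes, a question that plain phenyl at this place would help to separate. On these data alone, how an amine or a carboxylic acid on that ring would read in this assay also remains open.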